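A few compounds are considered here, and "the series" means these few. Any claim that something is new, unique, unknown or untested is made for them only; others in the source may bear on it.

Compound 2 `COc1cc(-c2nn(-c3cccc(NC(=O)Nc4ccc(Cl)c(Cl)c4)c3)cc2-c2ccncc2)ccc1Cl` and its two neighbours share one core and differ only at the edges. In a functional assay on SK-MEL-2 cells (Homo sapiens) for inhibition, read by sulforhodamine B assay, with a stated time of 48 h (on this read-out higher numbers stand for weaker inhibition of growth and lower numbers for stronger inhibition of growth), compound 2 gives 1140 nM. Compound 1 `COc1cc(-c2nn(-c3cccc(NC(=O)c4cccc(C(F)(F)F)c4)c3)cc2-c2ccncc2)ccc1Cl` gives 1560 nM, and compound 3 `O=C(Nc1cccc(-n2cc(-c3ccncc3)c(-c3ccc(Cl)c(O)c3)n2)c1)Nc1ccc(Cl)c(Cl)c1` gives 1030 nM; the number for compound 2 falls between those two, yet within the scatter of both. The step from compound 1 to compound 2, a 1.4-fold lower number from compound 1 to compound 2 (0.14 log units; within the scatter), exchanged the whole group on the carbonyl carbon; the step from compound 2 to compound 3, a 1.1-fold lower number from compound 2 to compound 3 (0.04 log units; within the scatter), was smaller still. Compound 4 `COc1cc(-c2nn(-c3cccc(NC(=O)Nc4ccc(Cl)c(C(F)(F)F)c4)c3)cc2-c2ccncc2)ccc1Cl` carries trifluoromethyl in place of chloro on an aromatic carbon. Both earlier steps bear on this change, and both stayed within the scatter, so no step beyond the scatter is expected in this assay. For compound 4 the expected value is 1000 nM, between 450 nM and 2300 nM, a step of a 1.1-fold lower number from compound 2 to compound 4 (0.06 log units; within the scatter) from compound 2.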

Compound 4, concentration for 50% growth inhibition: 1010 nM
Estimate against measurement, compound 4: 1.0-fold (0.00 log units) below, and the stated range covers the measured number.
By their numbers in this assay, from the lowest: compounds 4, 3, 2 and 1 (each within the scatter of the next).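

In this assay, a trifluoromethyl group of 4 heavy atoms takes the place of a chloro group of 1 heavy atom on this aromatic carbon, and the result stays within the scatter, with a 1.1-fold lower number from compound 2 to compound 4 (0.05 log units; within the scatter). The exchange of the whole group on the carbonyl carbon also stays within the scatter, with a 1.5-fold lower number from compound 1 to compound 4 (0.19 log units; within the scatter). No measurement here gives a reason for the size of either step. The compounds shown leave open whether an amine or a carboxylic acid on this same aromatic carbon would give a step beyond the scatter.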